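Quinazoline sulfonamides: swapping fluoro for chloro

A few compounds are considered here, and "the series" means these few. Any claim that something is new, unique, unknown or untested is made for them only; others in the source may bear on it.

Measured so far:
- compound 1, `COc1cc2ncnc(Nc3ccc(F)cc3)c2cc1OCCCCC(=O)Nc1ccc(S(N)(=O)=O)cc1`, > 40000 nM
- compound 2, `COc1cc2ncnc(Nc3ccc(Cl)cc3)c2cc1OCCCCC(=O)Nc1ccc(S(N)(=O)=O)cc1`, > 40000 nM
- compound 3, `NS(=O)(=O)c1ccc(NC(=S)Nc2ccc3ncnc(Nc4cccc(F)c4)c3c2)cc1`, 25900 nM

Of the compounds shown here, three have been tested in a functional assay on A549 cells (Homo sapiens) for antiproliferative activity, read by MTT assay, with a stated time of 72 h; a lower number here means a stronger inhibitor, a higher number a weaker inhibitor. Compound 1 reaches only the limit of the assay, > 40000 nM, and not a number. Compound 2 likewise reaches only a limit, > 40000 nM. Going by the values given here, compound 3 is the one compound that gives a real number, 25900 nM. The two limits are described by the limit of > 40000 nM in this assay, at which 2 of the 3 values shown sit.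

Compound 1 and compound 2 differ by a single change, (chloro in place of fluoro on an aromatic carbon), and the step is a step that the two limits leave unreadable from compound 1 to compound 2. Compound 3 carries a different core, and the difference between the two cores is not broken down here. Compound 4, `NS(=O)(=O)c1ccc(NC(=S)Nc2ccc3ncnc(Nc4cccc(Cl)c4)c3c2)cc1`, has not yet been measured; it differs from compound 3 by chloro in place of fluoro on an aromatic carbon. Among the compounds with values here, this is the same kind of change as the one from compound 1 to compound 2, but not the same: in the first pair the changed carbon sits para to a large group, in the second pair meta to a large group.

For compound 4 the step is expected to be a 1.3-fold lower number from compound 3 to compound 4 (0.11 log units; within the scatter), which rests on the value of compound 3, 25900 nM, and on the unreadable step from compound 1 to compound 2. Compound 4 is therefore estimated at 20000 nM, with a range from 7000 nM to 45000 nM.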

Compound 4, half-maximal inhibitory concentration: > 40000 nM
Compound 4 gave a limit, no number; the forecaster's own chance of this, stated with the estimate: 20%; at least 2.0-fold (0.30 log units) between middle value and limit.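

In this assay, compound 4 gives > 40000 nM, which is a limit of the assay and not a number. Chloro in place of fluoro on the core of compound 3, on an aromatic carbon meta to a large group, therefore reads as an at least 1.5-fold higher number from compound 3 to compound 4 (0.18 log units; that floor lies within the scatter), so only a floor for the step is known, and that floor does not show a change larger than the usual scatter of repeated measurements. The same swap on the core of compound 1 cannot be read, since compound 1 and compound 2 both stop at a limit, so this series shows neither that the change carries from one core to the other nor that it fails to, and the comparison is cut off at a single point: the limit of > 40000 nM in this assay, at which 3 of the 4 values shown sit.

Going by these compounds alone, compound 3 is the only compound here with a real number, so it remains open how far the true values of the other three lie from it. Also open, as far as these compounds go, is whether a different group in place of the fluoro of compound 3, such as a methoxy group, a nitrile or an amine, or a longer chain in place of the chain of compound 1, would give a measurable value in this assay.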